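Shifting one methoxy group: what to expect for compound 4

The source may report more compounds than this note shows. Statements on the series, on what has been measured and on what is new or still open speak of the compounds shown alone.

Compound 1 `COc1cccc(C(=O)n2c(-c3cn(C)c4ccc(OC)cc34)nc3ccccc32)c1` gives 11700 nM
Compound 2 `Cn1cc(-c2nc3ccccc3n2C(=O)c2ccccc2)c2cc(Br)ccc21` gives 48100 nM
Compound 3 `COc1ccccc1C(=O)n1c(-c2cn(C)c3ccc(Br)cc23)nc2ccccc21` gives 34600 nM

All three compounds were tested in a functional assay on HepG2 cells (Homo sapiens) for inhibition, read by MTT assay, with a stated time of 24 h (a higher number here means a weaker inhibitor of growth, a lower number a stronger inhibitor of growth), and compared by their numbers. Compound 3 stands level with compound 2, within the scatter, while its number is clearly higher than that of compound 1.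

The next compound, compound 4 `COc1cccc(C(=O)n2c(-c3cn(C)c4ccc(Br)cc34)nc3ccccc32)c1`, has the same atoms as compound 3, joined differently, as 3-methoxyphenyl in place of 2-methoxyphenyl on a carbonyl carbon shows. Here 3-methoxyphenyl takes the place of 2-methoxyphenyl on a carbonyl carbon.

Going by the values given here, no measured step shows this exact change. The closest evidence is a 1.4-fold lower number from compound 2 to compound 3 (0.14 log units; within the scatter) and this step, methoxy in place of hydrogen on an aromatic carbon, stayed within the scatter. Compound 1 also carries 3-methoxyphenyl, but on a different core. Its 11700 nM allows for a somewhat lower number, although the data cannot separate the two differences.

Overall, a 1.2-fold lower number from compound 3 to compound 4 (0.09 log units; within the scatter) is the expected step, and no change beyond the scatter is expected. For compound 4 the estimated value is 28000 nM in the middle of an expected range from 12000 nM to 60000 nM in this test.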

Compound 4, concentration for 50% growth inhibition: 17800 nM
Compound 4: middle estimate off by 1.6-fold (0.20 log units), on the high side; measured number inside the range.
By their numbers in this assay, from the lowest: compounds 1, 4, 3 and 2 (each within the scatter of the next, the first and the last beyond it).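

In this assay, putting 3-methoxyphenyl in place of 2-methoxyphenyl on a carbonyl carbon gives a 1.9-fold lower number from compound 3 to compound 4 (0.29 log units; within the scatter), so the two placements of the methoxy group cannot be told apart in this test. The step for adding methoxy now reads differently according to the group formed: forming 2-methoxyphenyl gave a 1.4-fold lower number from compound 2 to compound 3 (0.14 log units; within the scatter), while forming 3-methoxyphenyl gives a 2.7-fold lower number from compound 2 to compound 4 (0.43 log units; beyond the scatter), a modest step but the first for this addition to pass the scatter. Going by these compounds alone, with 3-methoxyphenyl held constant, the first direct comparison of the two core substituents, bromo in place of methoxy, gives a 1.5-fold higher number from compound 1 to compound 4 (0.18 log units; within the scatter), so these two compounds cannot be separated in this test.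

Nothing measured here offers an explanation for these numbers. The compounds shown leave open whether an amine or a carboxylic acid in place of the methoxy group on this ring would move the number beyond the scatter from compound 4, and whether a longer chain such as propoxy would do the same.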